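Aryl exchange on the shared core: compound 1 to compound 4

The source may hold more compounds than are shown below. What is called first, only, known or untested is meant among the compounds shown, and "the series" means these compounds.

Measured so far:
compound 1 `Cc1ccnc(NC(c2ccc3cccnc3c2O)c2c(F)cccc2Cl)c1` — > 40000 nM
compound 2 `Oc1ccc2[nH]ncc2c1C(c1ccc(-c2nccs2)cc1)N1CCCCC1` — 340 nM
compound 3 `Oc1c(C(Nc2ccccn2)c2ccc(Cl)cc2)ccc2cccnc12` — 170 nM

In an assay for inhibition of protein disulfide-isomerase (Homo sapiens), with a stated time of 1 h (on this read-out lower numbers stand for stronger inhibition and higher numbers for weaker inhibition), compound 1 gives > 40000 nM, which is a limit of the measurement and not a number. It therefore sits at the limit of > 40000 nM in this assay, at which 1 of the 3 values shown sits, the weakest end of what is shown. Compound 2 gives 340 nM and compound 3 gives 170 nM in this assay, both clear numbers.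

Compound 4 `CCc1ccc(C(Nc2cc(C)ccn2)c2ccc3cccnc3c2O)cc1` is not yet measured. It differs from compound 1 in one place: 4-ethylphenyl in place of 2-chloro-6-fluorophenyl on a saturated chain carbon bound to an aromatic carbon and a nitrogen on an aromatic ring. With a different group at that carbon on the shared core, compound 3 gives 170 nM, so an aryl change at this position is compatible with measurable inhibition.

For compound 4 a step toward stronger inhibition, beyond the scatter, is expected, as an at least 20-fold lower number from compound 1 to compound 4 (1.30 log units; beyond the scatter). Compound 4 is estimated at 2000 nM, within 300 nM to 15000 nM.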

Compound 4, half-maximal inhibitory concentration: 5390 nM
Compound 4: the middle estimate sits 2.7-fold (0.43 log units) below what was measured; low and high end bracket the measured number.
By their numbers in this assay, from the lowest: compounds 3 and 2 (each within the scatter of the next); then compound 4. At a limit, above all of these: compound 1.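

At this carbon of the shared core, 4-ethylphenyl in place of 2-chloro-6-fluorophenyl gives, in this assay, an at least 7.4-fold lower number from compound 1 to compound 4 (0.87 log units; beyond the scatter). Both groups have the same heavy-atom count and one six-membered aromatic ring of carbon only, so the aryl substituents alone are enough to shift the read-out. The full size of the step stays unknown, as compound 1 stands at a limit: the limit of > 40000 nM in this assay, at which 1 of the 4 values shown sits.

Still open, from the compounds shown here alone, is whether the step follows the loss of the chlorine and fluorine or the arrival of the ethyl. An unsubstituted phenyl or a phenyl bearing an amine at this carbon would separate the two.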